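The compounds below may be only part of what the source reports. "The series", "measured", "known", "first", "only" and "open" are said of these compounds alone.

Measured compounds:
Compound 1, `CNC(=O)[C@H]1O[C@@H](n2cnc3c(NOC)nc(I)nc32)[C@H](O)[C@@H]1O`, gives in an assay on CHO cells for displacement of a labelled ligand from adenosine receptor A1 (Homo sapiens) (a higher number here means a weaker inhibitor, a lower number a stronger inhibitor), a value of 153 nM.
Compound 2, `CNC(=O)[C@H]1O[C@@H](n2cnc3c(NOC)nc(C#Cc4ccccn4)nc32)[C@H](O)[C@@H]1O`, gives in this assay 3990 nM.
Compound 3, `CNC(=O)[C@H]1O[C@@H](n2cnc3c(NOC)nc(C#Cc4ccc(F)cc4)nc32)[C@H](O)[C@@H]1O`, gives in this assay 3000 nM.

Among the three numbers compound 3 stands second highest. Its nearest neighbour is compound 2, with a 1.3-fold lower number from compound 2 to compound 3 (0.12 log units; within the scatter), a difference inside the usual scatter, so nothing can be said about an order between these two. Its furthest neighbour is compound 1, with a 20-fold higher number from compound 1 to compound 3 (1.29 log units; beyond the scatter), a large step that parallels a 26-fold higher number from compound 1 to compound 2 (1.42 log units; beyond the scatter): replacing the iodo group on the aromatic carbon by either ethynyl-linked aryl group raised the number strongly.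

Compound 4, `CCNC(=O)[C@H]1O[C@@H](n2cnc3c(NOC)nc(C#Cc4ccc(F)cc4)nc32)[C@H](O)[C@@H]1O`, is not yet measured. It differs from compound 3 by methyl in place of hydrogen on a saturated chain carbon bound to an amide-type nitrogen. None of the three measured steps touches this place; all of them concern the substituent on the aromatic carbon of the shared core, and the amide end is identical in compounds 1, 2 and 3. Among the compounds with values here, there is thus no measured step that bears directly on this change, and the expectation for compound 4 is a step within the scatter, a 1.2-fold lower number from compound 3 to compound 4 (0.08 log units; within the scatter). Compound 4 is therefore estimated at 2500 nM, with a range from 900 nM to 7000 nM.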

Compound 4, inhibition constant: 1880 nM
Compound 4: the middle estimate sits 1.3-fold (0.12 log units) above what was measured, and the stated range covers the measured number.
By their numbers in this assay, from the lowest: compound 1; then compounds 4, 3 and 2 (each within the scatter of the next, the first and the last beyond it).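

In this assay, within the data shown here, the amide end of the molecule varies for the first time, and going from methylcarbamoyl to ethylcarbamoyl gives a 1.6-fold lower number from compound 3 to compound 4 (0.20 log units; within the scatter). Among these compounds, all the earlier steps concerned the substituent on the aromatic carbon of the shared core, where replacing iodo produced large steps, whereas this first reading at the amide end shows that, with the 2-(4-fluorophenyl)ethynyl group in place, one added methyl on the saturated chain carbon bound to the amide-type nitrogen leaves no difference that can be told from the scatter. Nothing shown offers an explanation for this outcome.

On these data alone, this single step comes from one background only, so it remains open whether ethyl in place of methyl would behave the same way with iodo or with the 2-(pyridin-2-yl)ethynyl group on the aromatic carbon. As far as these compounds go, it is also open how this position would respond to a larger change, such as a longer chain like propyl or butyl, a branched isopropyl, a cyclopropyl ring, or a hydroxyethyl chain carrying an alcohol.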